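Swapping hydroxy for amino on the shared core

The compounds below may be only part of what the source reports. "The series", "measured", "known", "first", "only" and "open" are said of these compounds alone.

Measured compounds:
compound 1, `CCOC(=O)N1CCC(NS(=O)(=O)c2ccc(NC(=O)c3ccccc3)c3ccccc23)CC1`, 0.17 nM in an assay on L1.2 cells for binding affinity to C-C chemokine receptor type 8 (Homo sapiens); on this read-out lower numbers stand for stronger inhibition and higher numbers for weaker inhibition
compound 2, `CCOC(=O)N1CCC(NS(=O)(=O)c2ccc(C(=O)NC3CCCCC3)c3ccccc23)CC1`, 9.5 nM in this assay
compound 3, `CCOC(=O)N1CCC(NS(=O)(=O)c2ccc(O)c3ccccc23)CC1`, which gives only a limit of > 5000 nM in this assay

Compound 3 stands at the weak end of the three: its value is a limit of the assay, not a number, so only a floor for its inhibition constant is known. The two steps that lead to it are both large: an at least 29000-fold higher number from compound 1 to compound 3 (4.46 log units; beyond the scatter) and an at least 520-fold higher number from compound 2 to compound 3 (2.72 log units; beyond the scatter). In both, a sizeable substituent on the aromatic carbon is replaced by a single hydroxy, and the binding collapses.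

Compound 4, `CCOC(=O)N1CCC(NS(=O)(=O)c2ccc(N)c3ccccc23)CC1`, differs from compound 3 by amino in place of hydroxy on an aromatic carbon. Within the data shown here, no measured step covers this exchange; the measured steps only show that a small group at this carbon leaves a very weak binder, whereas the large groups of compound 1 and compound 2 bind tightly. Since the amino group is as small as the hydroxy it replaces, compound 4 is expected to remain far from the potency of compound 1, and the step of an at least 1.6-fold lower number from compound 3 to compound 4 (0.22 log units; that floor lies within the scatter) is expected to be modest, with the result likely again near the limit of the assay. The estimate for compound 4 in this assay is 3000 nM, with a range from 400 nM to 20000 nM.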

Compound 4, inhibition constant: > 5000 nM
Compound 4 was reported as a limit; the forecaster's own chance of this, stated with the estimate: 50%; middle value at least 1.6-fold (0.22 log units) away from the limit.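

In this assay compound 4 gives > 5000 nM, which is a limit of the assay and not a number. Taking only the benzoyl off the nitrogen on the aromatic ring leaves an at least 29000-fold higher number from compound 1 to compound 4 (4.46 log units; beyond the scatter), so that nitrogen alone does not carry the binding, and exchanging cyclohexylcarbamoyl for amino leaves an at least 520-fold higher number from compound 2 to compound 4 (2.72 log units; beyond the scatter), so the large groups at this position now stand apart from both small groups shown. The step between the hydroxy and the amino compound cannot be read, and the two small groups cannot be told apart in this assay, as both values stop at the same limit: the limit of > 5000 nM in this assay, at which 2 of the 4 values shown sit.

The compounds shown leave open how much of the benzoyl is needed, for instance whether an acetyl group on the same nitrogen would already bring binding back or whether the phenyl ring is required. They also leave open whether a group of intermediate size, such as a methoxy group or a longer chain on this aromatic carbon, would give a value that can be read below the limit.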